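The source may hold more compounds than are shown below. What is called first, only, known or untested is meant among the compounds shown, and "the series" means these compounds.

Of the compounds shown here, three sharing one core have been measured in a functional assay on HT-29 cells (Homo sapiens) for antiproliferative activity, read by MTT assay, with a stated time of 72 h; on this read-out higher numbers stand for weaker inhibition and lower numbers for stronger inhibition. Compound 1 `Nc1nc(N)c2cc(CSC(=S)N3CCN(C4CCCCC4)CC3)ccc2n1` carries a cyclohexyl group on an amine nitrogen in a ring, and in this assay compound 1 gives 4050 nM. Compound 2 `Cc1ccccc1N1CCN(C(=S)SCc2ccc3nc(N)nc(N)c3c2)CC1` carries 2-methylphenyl in place of cyclohexyl on that nitrogen; in this assay compound 2 gives 2950 nM. Compound 3 `CC(=O)c1ccc(N2CCN(C(=S)SCc3ccc4nc(N)nc(N)c4c3)CC2)cc1` carries 4-acetylphenyl there instead; in this assay compound 3 gives 2280 nM. All the steps among them are small: a 1.4-fold lower number from compound 1 to compound 2 (0.14 log units; within the scatter), a 1.8-fold lower number from compound 1 to compound 3 (0.25 log units; within the scatter) and a 1.3-fold lower number from compound 2 to compound 3 (0.11 log units; within the scatter). Compound 2 therefore sits among three numbers that all lie within the scatter of one another, so none of the three can be called stronger or weaker than the others.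

Compound 4 `Nc1nc(N)c2cc(CSC(=S)N3CCN(c4ccccc4[N+](=O)[O-])CC3)ccc2n1` differs from compound 2 in one place: nitro in place of methyl on an aromatic carbon. The step from compound 2 to compound 3, where one aromatic group replaced another on the same nitrogen, stayed within the scatter, as did the two steps from the cyclohexyl compound to the aromatic ones. Nothing measured here shows a group on this aromatic ring moving the number beyond the scatter, so compound 4 is expected to give about 2600 nM, with a likely range from 1200 nM to 5500 nM. That would mean an expected step of a 1.1-fold lower number from compound 2 to compound 4 (0.05 log units; within the scatter).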

Compound 4, half-maximal inhibitory concentration: 4310 nM
The estimate for compound 4 lay 1.7-fold (0.22 log units) below the measured number; low and high end bracket the measured number.
By their numbers in this assay, from the lowest: compounds 3, 2, 1 and 4 (each within the scatter of the next).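

In this assay the exchange of methyl for nitro on an aromatic carbon ortho to a large group replaces one heavy atom with three and adds two hydrogen-bond acceptors, yet a 1.5-fold higher number from compound 2 to compound 4 (0.16 log units; within the scatter) is what results, so even this change in the group's make-up cannot be told apart from repeat-measurement noise. The other two new comparisons agree: a 1.9-fold higher number from compound 3 to compound 4 (0.28 log units; within the scatter) is the largest gap among the four compounds and still does not clear the scatter, while a 1.1-fold higher number from compound 1 to compound 4 (0.03 log units; within the scatter) shows that 2-nitrophenyl and cyclohexyl on the ring nitrogen cannot be separated, so none of the four groups tried on this nitrogen stands apart from the others. No measurement on hand speaks to why these numbers lie so close together.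

As far as these compounds go, what remains open is whether any group on this aromatic ring can move the number beyond the scatter, for example an amine or a carboxylic acid on the same carbon. Also open, from the compounds shown here alone, is whether a longer chain on the ring nitrogen, in place of the ring groups seen so far, would leave the number as little changed as these compounds do.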